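This account rests on a few compounds, and the source may have more. Where it says the series, first, only, none or still open, it means among the compounds named here.

Of the compounds shown here, three have been measured in a functional assay on SNB-19 cells (Homo sapiens) for cytotoxicity, read by sulforhodamine B assay, with a stated time of 48 h, tested at 10 uM; on this read-out lower numbers stand for a stronger effect and higher numbers for a weaker effect at the one concentration tested. Compound 3 `COc1ccc(C(=O)/C=C/c2cc(-c3cc(OC)c(OC)c(OC)c3)n[nH]2)cc1` gives -85%, and compound 2 `COc1ccc(C(=O)/C=C/c2cc(-c3cc(OC)c(OC)c(OC)c3)n[nH]2)cc1OC` gives -80%. The only difference between them is the change (methoxy in place of hydrogen on an aromatic carbon), and that change made the step of a number 5 percentage points higher from compound 3 to compound 2 (within the scatter). Compound 1 `COc1ccc(-c2cc(/C=C/C(=O)c3ccc(N)cc3)[nH]n2)cc1` gives 5% in this assay. The difference between the core of compound 1 and the core of compound 3 is not broken down here. For the measured compounds named here, compound 4 `COc1ccc(-c2cc(/C=C/C(=O)c3ccc(N)cc3)[nH]n2)cc1OC` has not been measured yet; it differs from compound 1 by the change (methoxy in place of hydrogen on an aromatic carbon), the same kind of change as the one from compound 3 to compound 2. Because that earlier step was a number 5 percentage points higher from compound 3 to compound 2 (within the scatter), a similarly small step is expected, namely a number 3 percentage points higher from compound 1 to compound 4 (within the scatter). For compound 4 the value expected in this assay is 8%, most likely between -10% and 25%.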

Compound 4, a percentage reported as activity, at one concentration (the size of the read-out at that concentration, not a potency): 31%
Estimate against measurement, compound 4: 23 percentage points below; the whole stated range lies below it.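

In this assay, adding the methoxy in place of hydrogen gives a number 26 percentage points higher from compound 1 to compound 4 (beyond the scatter). The size of the step therefore does not carry over unchanged from one core to the other: the same change on two cores in this assay, a number 5 percentage points higher (within the scatter) from compound 3 to compound 2 and a number 26 percentage points higher (beyond the scatter) from compound 1 to compound 4, 21 percentage points apart, beyond the scatter of two such steps. In these two pairs, the same change weakens the effect clearly on the core of compound 1 but not on the core of compound 3, yet two pairs give no general rule for other cores and do not explain the gap.

The compounds shown leave open how an ethoxy group or a chlorine on that same aromatic carbon would act on either core. Which part of the two cores goes with the larger step also remains open.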